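From 1,3-oxazol-5-yl to 5-fluoropyrimidin-2-yl

The compounds below may be only part of what the source reports. "The series", "measured", "known", "first", "only" and "open" are said of these compounds alone.

Within the data shown here, in a toxicity assay on HepG2 2.2.15 cells (Homo sapiens) for cytotoxicity, read by CellTiter-Glo (a higher number here means that more compound is tolerated, a lower number that less compound is tolerated), compound 1 `O=C1CC(C(F)(F)F)CN1c1cnn2c1CN(C(=O)Nc1cc(F)c(F)c(F)c1)C(C1CC1)C2` gives 115000 nM and compound 2 `O=C1CC(c2cnco2)CN1c1cnn2c1CN(C(=O)Nc1cc(F)c(F)c(F)c1)C(C1CC1)C2` gives 139000 nM so compound 2 stands within the scatter of the only other measured compound. Compound 3 `O=C1CC(c2ncc(F)cn2)CN1c1cnn2c1CN(C(=O)Nc1cc(F)c(F)c(F)c1)C(C1CC1)C2` has 5-fluoropyrimidin-2-yl in place of 1,3-oxazol-5-yl on a saturated ring carbon. Among the measured compounds shown here, the one measured step at that carbon (a 1.2-fold higher number from compound 1 to compound 2 (0.08 log units; within the scatter)) stayed within the scatter, so no step beyond the scatter is expected in this assay here. The expected change (a 1.2-fold lower number from compound 2 to compound 3 (0.08 log units; within the scatter)) is correspondingly small. Compound 3 is estimated at 115000 nM (expected range 60000 nM to 200000 nM).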

Compound 3, half-maximal cytotoxic concentration: 115000 nM
Beside the measured number, compound 3's estimate shows no gap at the digits printed; low and high end bracket the measured number.
By their numbers in this assay, from the lowest: compounds 1, 3 and 2 (each within the scatter of the next).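

In this assay, a six-membered aromatic ring on the saturated ring carbon gives a 1.2-fold lower number from compound 2 to compound 3 (0.08 log units; within the scatter) and no change at the digits printed from compound 1 to compound 3 (within the scatter). Trifluoromethyl, 1,3-oxazol-5-yl and 5-fluoropyrimidin-2-yl are therefore not told apart at this position in this assay, even though 5-fluoropyrimidin-2-yl has more heavy atoms than 1,3-oxazol-5-yl. Nothing available bears on the reason for this. On these data alone, whether an amine or a carboxylic acid on this carbon would give a step beyond the scatter remains open, as does whether a longer chain there would.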